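Extending the chain from compound 3 to compound 4

The source may report more compounds than this note shows. Statements on the series, on what has been measured and on what is new or still open speak of the compounds shown alone.

Measured so far in a functional assay on SW480 cells (Homo sapiens) for antiproliferative activity, read by MTT assay, with a stated time of 48 h (a higher number here means a weaker inhibitor, a lower number a stronger inhibitor), as limits only
compound 1 `CC(CCO)n1cnc2c(Cl)ncnc21` gives > 50000 nM as a limit
compound 2 `CCCCCC(CCO)n1cnc2c(Cl)ncnc21` gives > 50000 nM as a limit
compound 3 `C=C(CO)C(CCCCC)n1cnc2c(Cl)ncnc21` gives > 50000 nM as a limit

Compound 3 gives > 50000 nM as a limit and not as a number. Within the data shown here, the series so far stands at the limit of > 50000 nM in this assay, at which 3 of the 3 values shown sit, without exception, so compound 3 has no measured rank against compound 1 or compound 2.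

The next structure is compound 4 `C=C(CO)C(CCCCCCC)n1cnc2c(Cl)ncnc21` and the change from compound 3 is ethyl in place of hydrogen on a saturated chain carbon, six bonds along the chain from an aromatic nitrogen and a double-bonded chain carbon in full. Cut one bond further out, the same difference reads propyl to pentyl.

Among the measured compounds shown here, two measured steps bear on this change. The butyl step is a step that the two limits leave unreadable from compound 1 to compound 2 and has no readable size. The change from 2-hydroxyethyl to 1-(hydroxymethyl)ethenyl is a step that the two limits leave unreadable from compound 2 to compound 3 and has no readable size either. For the measured compounds named here, the nearest precedent is the butyl step, which is also a chain extension and gave no number on either side. No clear step is therefore expected in this assay and another limit is the likeliest report, with any shift expected towards stronger inhibition. The estimated step is an at least 1.2-fold lower number from compound 3 to compound 4 (0.09 log units; that floor lies within the scatter) on this reasoning. Compound 4 is estimated at 40000 nM with an expected range from 10000 nM to 50000 nM in this reading.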

Compound 4, half-maximal inhibitory concentration: 29400 nM
Beside the measured number, compound 4's estimate is 1.4-fold (0.13 log units) above it, within the range that was stated.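

In this assay, among these compounds, compound 4 is the first compound to return a number rather than a limit, 29400 nM, so this ethyl addition on a saturated chain carbon, six bonds along the chain from an aromatic nitrogen and a double-bonded chain carbon, gives the first step that can be read at all. That step is an at least 1.7-fold lower number from compound 3 to compound 4 (0.23 log units; that floor lies within the scatter), and it does not establish a real difference in this assay. Among the compounds shown here, its true size stays unknown, and the earlier steps cannot be read, because the other compounds all stop at one value: the limit of > 50000 nM in this assay, at which 3 of the 4 values shown sit.

The compounds shown leave open whether a longer chain at this place would bring a number clearly beyond the scatter, or whether an amine or a carboxylic acid at the chain end would do so. They also leave open whether the same ethyl addition would return a number with 2-hydroxyethyl in place of 1-(hydroxymethyl)ethenyl, which would show whether this reading depends on that group.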